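Ester Swap on an Anti-Inflammatory Oxalamide

The source may report more compounds than this note shows. Statements on the series, on what has been measured and on what is new or still open speak of the compounds shown alone.

The measured compounds and their values:
compound 1 `CCOC(=O)C(=O)Nc1cccccc1=O` gives 91%
compound 2 `CCOC(=O)C(=O)Nc1ccccc(C)c1=O` gives 34%
compound 3 `CCOC(=O)C(=O)Nc1ccccc(-c2ccccc2)c1=O` gives 0%

These three share one core and were tested in a functional assay on the whole organism (strain Sprague-Dawley CD) for inhibition, with Rattus norvegicus as the target, read by paw edema, at a dose of 100 mg/kg by the oral route; on this read-out higher numbers stand for a stronger effect at the one dose given and lower numbers for a weaker effect. Compound 1 stands highest of the three; its nearest neighbour is compound 2, reached by a number 57 percentage points lower from compound 1 to compound 2 (beyond the scatter), and compound 3 lies furthest, reached by a number 91 percentage points lower from compound 1 to compound 3 (beyond the scatter). The step of a number 34 percentage points lower from compound 2 to compound 3 (beyond the scatter) completes the picture: every addition on the aromatic carbon lowered the read-out beyond the scatter.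

Compound 4 `O=C(Nc1cccccc1=O)C(=O)Oc1ccccc1` is not yet measured. It differs from compound 1 by phenyl in place of ethyl on an oxygen next to a carbonyl group. Going by the values given here, this change sits on the ester oxygen, a place none of the measured steps touches; all three steps concern the ring. So no measured step bears directly on the step from compound 1 to compound 4, and the expectation rests only on compound 1 as the starting point with wide uncertainty. A moderate fall in this assay is expected, as a number 31 percentage points lower from compound 1 to compound 4 (beyond the scatter). For compound 4 the estimate is 60%, within 15% to 95%.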

Compound 4, a percentage reported as inhibition, in the whole organism at one dose (the size of the read-out at that dose, not a potency): 71%
Estimate against measurement, compound 4: 11 percentage points below; the range from low to high includes it.
By their numbers in this assay, from the lowest: compound 3; then compound 2; then compound 4; then compound 1.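

In this assay, the ester oxygen proves to be a place where phenyl can replace ethyl with most of the effect kept: the fall is real but modest (a number 20 percentage points lower from compound 1 to compound 4 (beyond the scatter)). The same phenyl group costs far more when it replaces hydrogen on the aromatic carbon (a number 91 percentage points lower from compound 1 to compound 3 (beyond the scatter)), so in these compounds the outcome depends on where the phenyl group sits. Nothing measured here accounts for this difference between the two places.

As far as these compounds go, it remains open how other groups on this oxygen would behave, such as a longer chain, a benzyl group, or the bare hydrogen of a carboxylic acid. The compounds shown also leave unclear whether a smaller ring or a substituted phenyl on this oxygen would follow compound 4.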